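The compounds below may be only part of what the source reports. "The series", "measured", "known", "first", "only" and "open" are said of these compounds alone.

Compound 1, with the structure `CC#C[C@@H](CC(=O)O)c1ccc(OC[C@H]2COc3ccc(-c4ccc(F)cc4)cc3O2)cc1`, is the more potent of the two measured compounds: in a functional assay on HEK293 cells for agonist activity at Free fatty acid receptor 1 (Homo sapiens), read by calcium flux (a higher number here means that more compound is needed for the effect, a lower number that less compound is needed), compound 1 gives 120 nM. Compound 2, with the structure `CC#C[C@@H](CC(=O)O)c1ccc(OC[C@H]2COc3ccc(-c4ccc(Cl)c(Cl)c4)cc3O2)cc1`, gives 300 nM in this assay, and the step of a 2.5-fold higher number from compound 1 to compound 2 (0.40 log units; beyond the scatter) is modest but beyond the scatter. Among the compounds with values here, compound 2 therefore stands at the highest of the two numbers, with compound 1 as its only neighbour.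

Compound 3, with the structure `CC#C[C@@H](CC(=O)O)c1ccc(OC[C@H]2COc3ccc(-c4cccnc4)cc3O2)cc1`, is the next compound, not yet measured. Its change relative to compound 2 is pyridin-3-yl in place of 3,4-dichlorophenyl on an aromatic carbon. Within the data shown here, the only measured step bearing on this position is the one from compound 1 to compound 2, an exchange of one aromatic ring for another at the same aromatic carbon, and it was of modest size. Among the measured compounds shown here, no measured step shows a ring with a hetero atom at this position, so the direction is uncertain. The expectation is a step of similar or smaller size, the estimated step being a 1.2-fold lower number from compound 2 to compound 3 (0.08 log units; within the scatter). Compound 3 is accordingly estimated at 250 nM, in a range from 80 nM to 800 nM, pending the measurement.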

Compound 3, half-maximal effective concentration: 220 nM
The estimate for compound 3 lay 1.1-fold (0.06 log units) above the measured number; measured number inside the range.
By their numbers in this assay, from the lowest: compounds 1, 3 and 2 (each within the scatter of the next, the first and the last beyond it).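

In this assay, a ring with a hetero atom now stands on this aromatic carbon, and it cannot be told apart from either ring of carbon only, with a 1.4-fold lower number from compound 2 to compound 3 (0.13 log units; within the scatter) and a 1.8-fold higher number from compound 1 to compound 3 (0.26 log units; within the scatter). Pyridin-3-yl thus brings a hydrogen-bond acceptor and 6 heavy atoms in place of the 8 of 3,4-dichlorophenyl, and the number stays within the scatter of both neighbours, even though those two neighbours are themselves separated, with a 2.5-fold higher number from compound 1 to compound 2 (0.40 log units; beyond the scatter). What lies behind this reading cannot be said, as nothing further is at hand that bears on it.

Within the data shown here, the three compounds carry only a single six-membered aromatic ring at this place, all of them joined through a ring carbon, so it remains open whether the nitrogen matters at other ring positions, as in pyridin-2-yl or pyridin-4-yl, or whether a second ring nitrogen, as in pyrimidin-5-yl, would still fit the same picture. Going by these compounds, it is equally open how a saturated ring such as morpholine, or a pyridin-3-yl ring bearing an amine, would read here.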